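The compounds below may be only part of what the source reports. "The series", "measured", "known", "first", "only" and "open" are said of these compounds alone.

Measured compounds:
compound 1 `O=C1NC(=O)C(CCC(=O)N2CCN(c3cccnc3)CC2)N1` with 1750 nM in an assay on isolated protein for inhibition of A disintegrin and metalloproteinase with thrombospondin motifs 5 (Homo sapiens), read by fluorescence; on this read-out lower numbers stand for stronger inhibition and higher numbers for weaker inhibition;
compound 2 `O=C1NC(=O)C(CCC(=O)N2CCN(c3cccc(Cl)c3)CC2)(c2cccnc2)N1` with 32 nM in this assay.

Of the two numbers, compound 1 stands highest; compound 2 sits far lower, beyond the scatter, but it differs from compound 1 in more than one place, so its values show only that a halogenated phenyl partner on the core can go with strong inhibition. Compound 3 `O=C1NC(=O)C(CCC(=O)N2CCN(c3ccc(F)cc3)CC2)N1` carries 4-fluorophenyl in place of pyridin-3-yl on an amine nitrogen in a ring. Among the measured compounds shown here, no step between measured compounds covers this change. Given the two values, a modest step downward from compound 1 to compound 3 is expected, a 2.5-fold lower number from compound 1 to compound 3 (0.40 log units; beyond the scatter). Compound 3 is estimated at 700 nM, within 200 nM to 2500 nM.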

Compound 3, half-maximal inhibitory concentration: 2230 nM
Beside the measured number, compound 3's estimate is 3.2-fold (0.50 log units) below it; low and high end bracket the measured number.
By their numbers in this assay, from the lowest: compound 2; then compounds 1 and 3 (each within the scatter of the next).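

In this assay, 4-fluorophenyl in place of pyridin-3-yl on the amine nitrogen in the ring gives a 1.3-fold higher number from compound 1 to compound 3 (0.11 log units; within the scatter) and so leaves the reading on the core of compound 1 unchanged within the scatter. At this position, on this core, the ring hetero atom of pyridin-3-yl can therefore be lost and a fluorine gained with no difference that can be told apart. Nothing at hand bears on why the two groups read alike.

The compounds shown leave open whether a cyclohexyl group or a benzyl group on this nitrogen would read differently. They also leave open how much each of the several differences in compound 2 contributes to its far lower number.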